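Same atoms, joined differently: from compound 1 to compound 3

This account rests on a few compounds, and the source may have more. Where it says the series, first, only, none or still open, it means among the compounds named here.

Compound 1 (`Cc1cc(C)c(CN2CCc3c(Cl)cc([C@H](CO)[C@H]4CCOC4)c(Cl)c3C2=O)c(=O)[nH]1`) and compound 2 (`COc1cc(C)[nH]c(=O)c1CN1CCc2c(Cl)cc([C@@H](O)C3COC3)c(Cl)c2C1=O`) have both been measured in a physicochemical assay for lipophilicity, at pH 7.4 (a higher number here means a more lipophilic compound, a lower number a more polar compound), so far. Compound 1 gives 2 and compound 2 gives 1.3 in this test, a gap beyond the scatter, which places compound 1 higher of the two. These two compounds differ in more than one place, so their gap cannot be tied to any single change.

Compound 3 (`Cc1cc(C)c(CN2CCc3c(Cl)cc([C@@H](CO)[C@H]4CCCO4)c(Cl)c3C2=O)c(=O)[nH]1`) has not been measured yet. It carries the same atoms as compound 1, joined differently: a group of 8 heavy atoms (6 carbon, 2 oxygen; one five-membered non-aromatic ring with 1 hetero atom) in place of a group of 8 heavy atoms (6 carbon, 2 oxygen; one five-membered non-aromatic ring with 1 hetero atom), on an aromatic carbon and the swap sits on an aromatic carbon, ortho to a chloro group, while the rest of the core stays the same. For the measured compounds named here, no measured pair shows a change of this kind, so the expectation starts from compound 1 at 2 and from the matching counts of the two groups. In this assay the expected result is a number 0.10 log units higher from compound 1 to compound 3 (within the scatter) as a small step, with no shift beyond the scatter in either direction. For compound 3 the estimated value is 2.1 with an expected range from 1.7 to 2.5 around it.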

Compound 3, distribution coefficient: 2.5
For compound 3 the middle estimate is 0.40 log units below the measured one, and the stated range covers the measured number.
By their numbers in this assay, from the lowest: compound 2; then compound 1; then compound 3.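

In this assay, the step is a number 0.50 log units higher from compound 1 to compound 3 (beyond the scatter), even though the group leaving and the group entering on this aromatic carbon, ortho to a chloro group, match in heavy atoms, ring type, hydrogen-bond donors and acceptors, and defined stereocentres. This shows that at this position, the read-out can move beyond the usual scatter when the same atoms are simply joined differently, so matching counts alone do not settle the number; the earlier pair could not show this, as compound 1 and compound 2 differ in more than one place. Nothing measured here explains why this rearrangement gives such a step.

This single step cannot separate the way the five-membered ring is joined to the rest of the group from the spatial arrangement at the two defined stereocentres, as the compounds shown do not vary these one at a time. It also leaves open how the read-out would respond to a different kind of group on this aromatic carbon, such as an amine or a carboxylic acid.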